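The source may hold more compounds than are shown below. What is called first, only, known or untested is meant among the compounds shown, and "the series" means these compounds.

Of the compounds shown here, two of a shared core have been measured so far. Compound 1 `O=C1N=C(C2C(=O)c3ccccc3C2=O)CC(c2ccccc2[N+](=O)[O-])N1` carries a 2-nitrophenyl on a saturated ring carbon, and in a functional assay on the whole organism for inhibition, with Rattus norvegicus as the target, read by paw edema, with stated times of 30 min and 4 h, at a dose of 10 mg/kg by the oral route (on this read-out higher numbers stand for more inhibition at the one dose given (going by the name of the read-out) and lower numbers for less inhibition), compound 1 gives 32%. Compound 2 `O=C1N=C(C2C(=O)c3ccccc3C2=O)CC(c2ccc(Cl)cc2)N1` carries a 4-chlorophenyl in the same place, and in this assay compound 2 gives 34%. Within the data shown here, the one measured step, a number 2 percentage points higher from compound 1 to compound 2 (within the scatter), is told to lie within the scatter. Among the two numbers compound 2 therefore stands alongside compound 1, the gap between them being within the scatter.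

Compound 3 `O=C1N=C(C2C(=O)c3ccccc3C2=O)CC(c2ccco2)N1` differs from compound 2 in one place: furan-2-yl in place of 4-chlorophenyl on a saturated ring carbon. Among the measured compounds shown here, the only step that bears on this change is the earlier swap of one aryl group for another on the same saturated ring carbon, and that step, a number 2 percentage points higher from compound 1 to compound 2 (within the scatter), did not leave the scatter. Nothing is known here of a furan-2-yl in this series. The expected step is a number 2 percentage points lower from compound 2 to compound 3 (within the scatter), that is, none beyond the scatter. In this assay compound 3 is estimated at 32%, with a range from 20% to 44%.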

Compound 3, a percentage reported as inhibition, in the whole organism at one dose (the size of the read-out at that dose, not a potency): 7%
Compound 3: middle estimate off by 25 percentage points, on the high side, outside the stated range (below it).
By their numbers in this assay, from the lowest: compound 3; then compounds 1 and 2 (each within the scatter of the next).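

At the saturated ring carbon of the shared core, this assay does respond to the group carried there: furan-2-yl in place of 4-chlorophenyl gives a number 27 percentage points lower from compound 2 to compound 3 (beyond the scatter) and furan-2-yl in place of 2-nitrophenyl gives a number 25 percentage points lower from compound 1 to compound 3 (beyond the scatter) in the same read-out. The earlier swap, between two substituted phenyl groups, had stayed within the scatter, so the position first shows a difference beyond the scatter when the six-membered aromatic ring of carbon only gives way to a five-membered aromatic ring with 1 hetero atom. No measurement at hand explains this drop or says which part of the change matters.

The three compounds do not separate the smaller ring from its ring oxygen or from the loss of the substituent that both phenyl groups carry. An unsubstituted phenyl, a thiophen-2-yl or a furan-3-yl at this carbon would bear on those questions, while a cyclohexyl would test whether an aromatic ring is needed there at all.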